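Swapping a benzyl substituent on the triazole of a dithiocarbamate

The compounds below may be only part of what the source reports. "The series", "measured", "known", "first", "only" and "open" are said of these compounds alone.

Three compounds share a triazole-linked dithiocarbamate core. Compound 1 `Cc1ccc(-n2cc(CSC(=S)N3CCN(C(=O)OC(C)(C)C)CC3)nn2)cc1` gives 48300 nM in a functional assay on MGC-803 cells (Homo sapiens) for inhibition, read by MTT assay, with a stated time of 72 h; a higher number here means a weaker inhibitor, a lower number a stronger inhibitor. Compound 2 `S=C(SCc1cn(Cc2ccccc2Cl)nn1)N1CCNCC1` gives 45200 nM in this assay, and compound 3 `COc1ccc(Cn2cc(CSC(=S)N3CCN(C(=O)OC(C)(C)C)CC3)nn2)cc1` gives 22800 nM. For the measured compounds named here, compound 3 thus has the lowest of the three numbers, but its gap to compound 2 falls within the usual scatter, so only the step of a 2.1-fold lower number from compound 1 to compound 3 (0.33 log units; beyond the scatter) counts as a real difference.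

Compound 4 `CC(C)(C)OC(=O)N1CCN(C(=S)SCc2cn(Cc3ccccc3Cl)nn2)CC1` differs from compound 3 in one place: 2-chlorophenyl in place of 4-methoxyphenyl on a saturated chain carbon bound to an aromatic nitrogen. Going by the values given here, no measured step covers this exact change. Among the compounds with values here, compound 2 carries the same 2-chlorobenzyl group, yet it also lacks the carbamate on the saturated ring, so its value shows only that this group sits in the same broad range. Within the data shown here, the one measured step, from compound 1 to compound 3, concerns a different exchange and was modest.

Among the measured compounds shown here, with no direct precedent, compound 4 is expected to land close to compound 3, a step of a 1.3-fold higher number from compound 3 to compound 4 (0.12 log units; within the scatter) not beyond the scatter. The estimate for compound 4 in this assay is 30000 nM, ranging from 12000 nM to 75000 nM.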

Compound 4, half-maximal inhibitory concentration: 490 nM
Beside the measured number, compound 4's estimate is 61-fold (1.79 log units) above it; measured number outside the range, below it.
By their numbers in this assay, from the lowest: compound 4; then compounds 3, 2 and 1 (each within the scatter of the next, the first and the last beyond it).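

In this assay, for the compounds shown here, the group on the aromatic nitrogen proves far more decisive than the earlier compounds showed: 2-chlorobenzyl in place of 4-methoxybenzyl brings a 47-fold lower number from compound 3 to compound 4 (1.67 log units; beyond the scatter), while the earlier exchange at this nitrogen brought only a 2.1-fold lower number from compound 1 to compound 3 (0.33 log units; beyond the scatter). The tert-butoxycarbonyl group on the ring amine nitrogen counts as well, with a 92-fold lower number from compound 2 to compound 4 (1.96 log units; beyond the scatter), and changing both places at once gives a 99-fold lower number from compound 1 to compound 4 (1.99 log units; beyond the scatter), so among these compounds the low number appears only where 2-chlorobenzyl and tert-butoxycarbonyl occur together. No measurement offered here explains why these changes have such large effects.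

A plain benzyl or a 4-chlorobenzyl group on the same core would test how much of the gain depends on the exact 2-chlorobenzyl group. As far as these compounds go, it also remains open whether an acetyl group on the ring amine nitrogen could stand in for tert-butoxycarbonyl.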